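The source may report more compounds than this note shows. Statements on the series, on what has been measured and on what is new or still open speak of the compounds shown alone.

Measured in a functional assay on HL-60 cells (Homo sapiens) for inhibition, read by MTT assay, with a stated time of 48 h, tested at 10 uM; a higher number here means more inhibition of growth at the concentration tested, a lower number less inhibition of growth:
- compound 1 `Cc1cc(=O)c2c(O)c(CN3CCCCC3)c(O)c([C@H]3CCN(C)C[C@H]3O)c2o1`: 32%
- compound 2 `Cc1oc2c([C@H]3CCN(C)C[C@H]3O)c(O)cc(O)c2c(=O)c1C(O)c1ccc([N+](=O)[O-])cc1`: 0%
- compound 3 `Cc1oc2c([C@H]3CCN(C)C[C@H]3O)c(O)cc(O)c2c(=O)c1C(O)c1ccc(Cl)cc1`: 2%

Compound 3 gives 2%, which lies within the scatter of compound 2 at 0%. Compound 1, at 32%, lies beyond the scatter of both, so compound 3 belongs to the low pair of this small set.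

The next compound to be tested is compound 4 `Cc1oc2c([C@H]3CCN(C)C[C@H]3O)c(O)cc(O)c2c(=O)c1C(O)c1cccc(Cl)c1`. It has 3-chlorophenyl in place of 4-chlorophenyl on a saturated chain carbon bound to an aromatic carbon and an oxygen on a saturated carbon. The atoms stay the same and only their arrangement differs.

Among the compounds with values here, one measured step bears on this change, and only indirectly: a number 2 percentage points higher from compound 2 to compound 3 (within the scatter). That step put chloro in place of nitro on an aromatic carbon and left the number within the scatter. Within the data shown here, no measured pair tests moving the chlorine, so this evidence is thin. Compound 1 offers no single-change comparison with compound 4.

With nothing pointing to a larger shift, no change beyond the scatter is expected in this assay. The expected step is a number 1 percentage points higher from compound 3 to compound 4 (within the scatter). For compound 4 the estimated value is 3%, with an expected range from 0% to 12%.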

Compound 4, percent growth inhibition at one concentration: 22%
Compound 4: middle estimate off by 19 percentage points, on the low side; the measured number lies above the stated range.
By their numbers in this assay, from the lowest: compounds 2 and 3 (each within the scatter of the next); then compounds 4 and 1 (each within the scatter of the next).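

In this assay the step of a number 20 percentage points higher from compound 3 to compound 4 (beyond the scatter) comes from replacing 4-chlorophenyl with 3-chlorophenyl on the saturated chain carbon, even though the two compounds contain the same atoms, joined differently. Until now, this site had seemed insensitive to change, since replacing nitro with chloro left the number within the scatter; the step of a number 22 percentage points higher from compound 2 to compound 4 (beyond the scatter) with 3-chlorophenyl in place of 4-nitrophenyl confirms that the change at this site can matter, and that the arrangement of the ring substituent, not just its identity, affects growth inhibition at the concentration tested. Nothing available explains why this rearrangement changes the number.

The compounds shown cover only this one shift of the chlorine, so it remains open whether 2-chlorophenyl or 3-nitrophenyl on the same carbon would give a number like that of 3-chlorophenyl or like that of 4-chlorophenyl. Going by these compounds, it is also open whether the effect depends on chlorine itself, which a group such as 3-methoxyphenyl or 3-fluorophenyl at this site could help to test.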